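Swapping a Branched Chain for an Ether-Bearing Chain

A few compounds are considered here, and "the series" means these few. Any claim that something is new, unique, unknown or untested is made for them only; others in the source may bear on it.

Measured so far:
compound 1, `CNC(=O)c1cc(C(=O)NCC(C)C)cn(Cc2ccccc2)c1=O`: 43 ug/mL
compound 2, `CNC(=O)c1cc(C(=O)NC2CCC2)cn(Cc2cccnc2)c1=O`: a limit, >= 99 ug/mL

Within the data shown here, in a physicochemical assay for solubility (a higher number here means a more soluble compound, a lower number a less soluble compound), compound 1 gives 43 ug/mL, the only plain number among the two measured compounds. Compound 2 returns only a limit, >= 99 ug/mL; this is the limit of >= 99 ug/mL in this assay, at which 1 of the 2 values shown sits, not a measured number. Among the measured compounds shown here, the two compounds differ in more than one place, so no single step between them can be read off.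

Compound 3, `CNC(=O)c1cc(C(=O)NCCOC)cn(Cc2ccccc2)c1=O`, is not yet measured. It differs from compound 1 in one place: methoxymethyl in place of isopropyl on a saturated chain carbon bound to an amide-type nitrogen. For the measured compounds named here, no measured pair shows this change on its own, so the expectation rests on the starting point alone. A modest rise in this assay is expected, one that may reach the limit of the assay. Compound 3 is expected to give 85 ug/mL, with a range from 40 ug/mL to 180 ug/mL. The step expected is a 2.0-fold higher number from compound 1 to compound 3 (0.30 log units; within the scatter).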

Compound 3, solubility: >= 164 ug/mL
Compound 3 ended at the assay's limit (the forecaster's own chance of this, stated with the estimate: 40%); middle value at least 1.9-fold (0.28 log units) from the limit.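

Among these compounds, compound 1 and compound 3 are the first pair that differ in one place, so this position can now be read on its own: in this assay, methoxymethyl in place of isopropyl on a saturated chain carbon bound to an amide-type nitrogen gives an at least 3.8-fold higher number from compound 1 to compound 3 (0.58 log units; beyond the scatter). Both groups hold 3 heavy atoms, so the count stays the same while one carbon gives way to an oxygen, which brings in 1 hydrogen-bond acceptor. Compound 3 gives a limit rather than a plain number, so the full size of this step stays unknown: the limit of >= 164 ug/mL in this assay, at which 1 of the 3 values shown sits.

This single pair cannot show whether the same swap would work as well on other compounds. It also leaves open how a longer chain ending in a methoxy group, or an amine or a carboxylic acid, would behave at this place.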